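The compounds below may be only part of what the source reports. "The series", "measured", "known", "first", "only" and "open" are said of these compounds alone.

Working notes on the chalcone-type series in a functional assay on HepG2 cells (Homo sapiens) for inhibition, read by MTT assay, with a stated time of 72 h; on this read-out higher numbers stand for weaker inhibition and lower numbers for stronger inhibition.

Compound 1 `COc1cc(O)cc(O)c1C(=O)/C=C/c1ccc(O)cc1` gives 40200 nM in this assay, the highest of the three numbers recorded so far. Within the data shown here, its nearest neighbour is compound 3 `COc1cc(O)cc(O)c1C(=O)/C=C/c1ccc(O)c(O)c1`, which gives 28700 nM; the step of a 1.4-fold lower number from compound 1 to compound 3 (0.15 log units; within the scatter) is the only single-change step in the set. Among the measured compounds shown here, compound 2 `COc1ccccc1/C=C/C(=O)c1c(O)cc(O)cc1OC` gives 15300 nM, a number that lies beyond the scatter from that of compound 1, though the two structures differ in more than one place and no single step connects them.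

Compound 4 `COc1cc(O)cc(O)c1C(=O)/C=C/c1ccc(C(F)(F)F)cc1` is not yet measured. Relative to compound 1 the change is trifluoromethyl in place of hydroxy on an aromatic carbon, para to a large group. For the measured compounds named here, no measured step in the set touches this position with a trifluoromethyl, and the one step that does alter the same ring, from compound 1 to compound 3, stayed within the scatter. On the evidence available, therefore, no step beyond the scatter is expected in this assay , in either direction, with the uncertainty left open by the absence of a comparable step.

Compound 4 is accordingly estimated at 32000 nM, in the range 10000 nM to 100000 nM. The expected step is a 1.3-fold lower number from compound 1 to compound 4 (0.10 log units; within the scatter). Going by the values given here, its size is taken from the only single-change step measured so far, a 1.4-fold lower number from compound 1 to compound 3 (0.15 log units; within the scatter).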

Compound 4, half-maximal inhibitory concentration: 14100 nM
Beside the measured number, compound 4's estimate is 2.3-fold (0.36 log units) above it, within the range that was stated.
By their numbers in this assay, from the lowest: compounds 4, 2, 3 and 1 (each within the scatter of the next, the first and the last beyond it).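

In this assay, among these compounds, trifluoromethyl in place of hydroxy on an aromatic carbon, para to a large group, gives a 2.9-fold lower number from compound 1 to compound 4 (0.46 log units; beyond the scatter), the first single change to lie beyond the scatter. Among the compounds shown here, the number at this position therefore responds to the group placed there, which the only earlier step on this ring, a 1.4-fold lower number from compound 1 to compound 3 (0.15 log units; within the scatter), did not show, as that step added a hydroxy, stayed within the scatter and left the existing hydroxy in place. The result also shows that this hydroxy, with its hydrogen-bond donor and acceptor, is not needed to reach the lower number in this assay, although no measured property on these compounds accounts for the size or direction of the step.

A single replacement does not separate the loss of the hydroxy from the entry of the trifluoromethyl, so the contribution of each remains unresolved. The compounds shown also leave open how a hydrogen, a chlorine, a methoxy, an amine or a carboxylic acid at the same place on the core of compound 1 would compare with the trifluoromethyl of compound 4.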